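Working notes: substitution on the ring nitrogen, compound 4

The source may report more compounds than this note shows. Statements on the series, on what has been measured and on what is new or still open speak of the compounds shown alone.

Measured so far in a functional assay on HT-1080 cells (Homo sapiens) for inhibition, read by MTT assay, with a stated time of 48 h; a lower number here means a stronger inhibitor, a higher number a weaker inhibitor:
- compound 1 `COc1cc(-c2nc3cc(/C=C4\SC(=O)NC4=O)ccc3[nH]2)cc(OC)c1OC`: 3120 nM
- compound 2 `COc1ccc(-c2nc3cc(/C=C4\SC(=O)NC4=O)ccc3[nH]2)cc1OC`: 2430 nM
- compound 3 `COc1cc(OC)c(-c2nc3cc(/C=C4\SC(=O)N(CC(=O)N5CCOCC5)C4=O)ccc3[nH]2)cc1OC`: 1120 nM

Compound 1 stands at the highest number of the three. Its nearest neighbour is compound 2, and the gap a 1.3-fold lower number from compound 1 to compound 2 (0.11 log units; within the scatter) is within the scatter, so the two cannot be ordered. Compound 3 lies further off, at a lower number than compound 1 beyond the scatter, but compound 3 differs from compound 1 in two places at once, so no single step can be read from that pair.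

Compound 4 `COc1cc(-c2nc3cc(/C=C4\SC(=O)N(Cc5cccc(C)c5)C4=O)ccc3[nH]2)cc(OC)c1OC` is not yet measured. It differs from compound 1 by 3-methylbenzyl in place of hydrogen on an amide-type nitrogen in a ring. None of the measured steps touches this ring nitrogen: the one listed step, from compound 1 to compound 2, concerns a methoxy group and is within the scatter. Going by the values given here, compound 3 is the only compound carrying a group on that nitrogen, and its lower number is the only hint available, though confounded by its altered methoxy pattern.

On that thin basis a modest lowering is expected for compound 4, a 2.1-fold lower number from compound 1 to compound 4 (0.32 log units; beyond the scatter), with wide uncertainty. The estimate for compound 4 in this assay is 1500 nM, in the range 500 nM to 5000 nM.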

Compound 4, half-maximal inhibitory concentration: 4580 nM
Beside the measured number, compound 4's estimate is 3.1-fold (0.48 log units) below it, and the stated range covers the measured number.
By their numbers in this assay, from the lowest: compound 3; then compounds 2, 1 and 4 (each within the scatter of the next).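

In this assay, going by these compounds alone, this is the first single-change reading at the amide-type nitrogen in the five-membered non-aromatic ring: 3-methylbenzyl in place of hydrogen gives a 1.5-fold higher number from compound 1 to compound 4 (0.17 log units; within the scatter). The nitrogen therefore carries a group of this size, with its six-membered aromatic ring, without a difference from the hydrogen of compound 1 that can be read, and this step gives no support to the idea that any group on this nitrogen lowers the number, while compound 3 still differs from compound 1 in two places and cannot settle the matter alone. Nothing available explains this result, so the reading stays purely descriptive.

Still open, on these data alone, is how much of the number of compound 3 belongs to its morpholine amide side chain and how much to its methoxy pattern, a question that the same side chain on the core of compound 1 would address directly. Also open, as far as these compounds go, is whether a carboxylic acid, a tertiary amine on a longer chain, or an unsubstituted benzyl group on this nitrogen would give a step beyond the scatter from compound 1.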